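The compounds below may be only part of what the source reports. "The series", "measured", "known", "first", "only" and "open" are said of these compounds alone.

Compound 1 `O=C1c2ccccc2C(=O)N1CCOC(=S)N(C(=O)c1ccccc1[N+](=O)[O-])c1ccc(Cl)cc1` gives 21000 nM in an ADME assay on MT4 cells (Homo sapiens) for cytotoxicity, read by MTT assay; a higher number here means that more compound is tolerated, a lower number that less compound is tolerated.
Compound 2 `Cc1ccc(N(C(=O)c2ccccc2[N+](=O)[O-])C(=S)OCCN2C(=O)c3ccccc3C2=O)cc1` gives 100000 nM in this assay.
Compound 3 `O=C1c2ccccc2C(=O)N1CCOC(=S)N(C(=O)c1ccc(Cl)cc1Cl)c1ccc(Cl)cc1` gives 18000 nM in this assay.

Compound 2 stands highest of the three, with compound 1 next, a step of a 4.8-fold higher number from compound 1 to compound 2 (0.68 log units; beyond the scatter), and compound 3 furthest off. Compound 4 `Cc1ccc(N(C(=O)c2cccc(Cl)c2Cl)C(=S)OCCN2C(=O)c3ccccc3C2=O)cc1` has not yet been measured; it differs from compound 2 in one place: 2,3-dichlorophenyl in place of 2-nitrophenyl on a carbonyl carbon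

Within the data shown here, the closest precedent is the step from compound 1 to compound 3, where a 2,4-dichlorophenyl replaced the 2-nitrophenyl on the same carbonyl carbon: a 1.2-fold lower number from compound 1 to compound 3 (0.07 log units; within the scatter). That change left the number essentially where it was. Among the measured compounds shown here, the change to compound 4 puts the second chlorine in a different spot on the ring, so it is a near but not exact match, and only one such step is available. On that basis the expectation is a step for compound 4 of a 1.2-fold lower number from compound 2 to compound 4 (0.07 log units; within the scatter), with no movement beyond the scatter. The estimate for compound 4 is therefore 85000 nM, within a range of 30000 nM to 200000 nM.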

Compound 4, half-maximal cytotoxic concentration: 35000 nM
The estimate for compound 4 lay 2.4-fold (0.39 log units) above the measured number, and the stated range covers the measured number.
By their numbers in this assay, from the lowest: compounds 3, 1 and 4 (each within the scatter of the next); then compound 2.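

In this assay, replacing the 2-nitrophenyl on this carbonyl carbon with a dichlorophenyl does not always leave the number unchanged: the present change gives a 2.9-fold lower number from compound 2 to compound 4 (0.46 log units; beyond the scatter) while the earlier one gave a 1.2-fold lower number from compound 1 to compound 3 (0.07 log units; within the scatter) in the series carrying chlorine in place of methyl. This position can therefore respond to the change, although the two steps differ both in the chlorine pattern and in the methyl or chloro group elsewhere on the core, so the compounds shown cannot separate these two differences. Nothing at hand explains the larger step.

Going by these compounds, it remains open whether 2,4-dichlorophenyl on the core of compound 2 would behave like 2,3-dichlorophenyl. On these data alone, how an unsubstituted phenyl or a methoxyphenyl at this carbonyl carbon would compare with either group also remains open.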